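The source may report more compounds than this note shows. Statements on the series, on what has been measured and on what is new or still open speak of the compounds shown alone.

Compound 2 `COc1cc(-c2ccnc3cc(-c4ccc(C(C)(C)C)cc4)nn23)cc(OC)c1OC` is one of three compounds in this study, and in a functional assay on HeLa cells (Homo sapiens) for inhibition, read by CCK-8 assay, with a stated time of 48 h (a higher number here means a weaker inhibitor, a lower number a stronger inhibitor), compound 2 gives > 10000 nM, which is a limit of the assay rather than a measured number. Compound 1 `COc1cc(-c2ccnc3c(-c4ccc(C)cc4)cnn23)cc(OC)c1OC` gives > 10000 nM in this assay, again a limit. Compound 3 `Cc1ccc(-c2cc3nccc(-c4ccc(F)cc4)n3n2)cc1` gives > 10000 nM in this assay, also a limit. All three values therefore sit at the limit of > 10000 nM in this assay, at which 3 of the 3 values shown sit, so compound 2 cannot be placed above or below the other two; it simply shares their position at the limit.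

Compound 4 `COc1cc(-c2ccnc3cc(-c4ccc5c(ccn5C)c4)nn23)cc(OC)c1OC` is the compound not yet measured, and it differs from compound 2 by 1-methyl-1H-indol-5-yl in place of 4-(tert-butyl)phenyl on an aromatic carbon.

Among the compounds with values here, no step between measured compounds is available, since every value is a limit, so nothing here shows how a change of this kind moves the readout. With three limits and no graded value, the expected step is small, and only a change beyond the scatter toward a stronger inhibitor would bring compound 4 out of the limit. Compound 4 is expected to give 9000 nM in this assay, with a range from 2000 nM to 30000 nM, and the step of an at least 1.1-fold lower number from compound 2 to compound 4 (0.04 log units; that floor lies within the scatter) is the change this estimate expects.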

Compound 4, half-maximal inhibitory concentration: 19 nM
The estimate for compound 4 lay 470-fold (2.68 log units) above the measured number; the whole stated range lies above it.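

In this assay, within the data shown here, the earlier compounds gave only limits, so they did not show that this position could move the readout at all. Placing 1-methyl-1H-indol-5-yl in place of 4-(tert-butyl)phenyl on this aromatic carbon gives an at least 520-fold lower number from compound 2 to compound 4 (2.72 log units; beyond the scatter), so the group at this position can separate a compound at the limit from one with a measured value. This size is a floor rather than a measured step, since compound 2 stands at a limit: the limit of > 10000 nM in this assay, at which 3 of the 4 values shown sit.

Among these compounds, the single pair does not say whether the added five-membered aromatic ring, its ring nitrogen or the methyl group on that nitrogen carries the change. It also leaves open how an indol-5-yl group without the methyl, or a phenyl group bearing a methoxy group or an amine, would behave here.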